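The source may hold more compounds than are shown below. What is called first, only, known or untested is meant among the compounds shown, and "the series" means these compounds.

In a toxicity assay on HEK-293T cells (Homo sapiens) for inhibition, read by MTT assay, with a stated time of 24 h (a lower number here means that less compound is tolerated, a higher number that more compound is tolerated), compound 1 (`O=c1oc2ccccc2c(N2CCN(c3ccccc3)CC2)c1CO`) gives > 50000 nM as its reading, which is a limit of the assay and not a number. Compound 2 (`O=c1oc2ccccc2c(N2CCN(C(c3ccc(F)cc3)c3ccc(F)cc3)CC2)c1CO`) gives > 50000 nM as its reading, and this too is a limit. Among the compounds with values here, the picture so far is therefore the limit of > 50000 nM in this assay, at which 2 of the 2 values shown sit, with no measured step between two compounds to go by.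

Compound 3 (`O=c1oc2ccccc2c(N2CCN(c3ccc(F)cc3)CC2)c1CO`) keeps the core of compound 1 and differs from it in one place. The phenyl group becomes 4-fluorophenyl, with fluoro in place of hydrogen on an aromatic carbon, para to a large group (fluoro in place of hydrogen on an aromatic carbon). Within the data shown here, it is a small edit, and the only guide to its effect is where compound 1 stands.

Compound 1 stands at > 50000 nM as a limit, so in this assay no step beyond the usual scatter is expected for this change. The estimated move is a step that the limit leaves unreadable from compound 1 to compound 3 in size, and another reading at the limit is the likeliest result. For compound 3 the estimated value is 60000 nM with an expected range from 30000 nM to 120000 nM around it.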

Compound 3, half-maximal cytotoxic concentration: > 50000 nM
Compound 3 was reported as a limit; the forecaster's own chance of this, stated with the estimate: 85%; the middle value lies beyond the limit too.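

In this assay, within the data shown here, compound 1 and compound 3 both read as limits and not as numbers, so no step between them can be read, and all three compounds share one reading: the limit of > 50000 nM in this assay, at which 3 of the 3 values shown sit.

The compounds shown leave open at what concentration any of them would harm these cells, and whether fluoro in place of hydrogen changes that concentration at all.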